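The source may report more compounds than this note shows. Statements on the series, on what has been measured and on what is new or still open speak of the compounds shown alone.

Three related compounds have been tested for their ability to kill cultured human tumour cells. Compound 1 `COc1ccc(-c2cc(/C=C/C(=O)c3ccc(N)cc3)[nH]n2)cc1` and compound 2 `COc1ccc(-c2cc(/C=C/C(=O)c3ccc(N)cc3)[nH]n2)cc1OC` share one core, while compound 3 `COc1cc(C(=O)/C=C/c2cc(-c3cc(OC)c(OC)c(OC)c3)n[nH]2)cc(OC)c1OC` carries more methoxy groups. In a functional assay on SF-268 cells (Homo sapiens) for cytotoxicity, read by sulforhodamine B assay, with a stated time of 48 h, tested at 1 uM (a higher number here means a weaker effect of the compound at the concentration tested, a lower number a stronger effect), compound 2 gives 88%, and compound 1 gives 78%. The structural change between these two is hydrogen in place of methoxy on an aromatic carbon and it produced a number 10 percentage points lower from compound 2 to compound 1 (within the scatter). In this assay compound 3 gives 89%. How the core of compound 3 differs from the core of compound 2 is not broken down here, since the two differ in more than one place. Set against compound 2, the number for compound 3 lies within the scatter; set against compound 1, it lies beyond it.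

Compound 4 `COc1ccc(-c2cc(/C=C/C(=O)c3cc(OC)c(OC)c(OC)c3)[nH]n2)cc1OC` has not yet been measured. It is derived from compound 3 by hydrogen in place of methoxy on an aromatic carbon. The surroundings are not identical to those in the earlier pair: in compound 3 the carbon that loses its group is also meta to a methoxy group, so this counts as the same kind of change rather than the same change. Because the earlier pair gave a number 10 percentage points lower from compound 2 to compound 1 (within the scatter), compound 4 is expected to show a step of about a number 7 percentage points lower from compound 3 to compound 4 (within the scatter), again within the scatter. The estimate for compound 4 in this assay is 82%, with an expected range from 70% to 93%.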

Compound 4, a percentage reported as activity, at one concentration (the size of the read-out at that concentration, not a potency): 81%
The estimate for compound 4 lay 1 percentage points above the measured number; the range from low to high includes it.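

Putting hydrogen in place of methoxy on an aromatic carbon gave a number 8 percentage points lower from compound 3 to compound 4 (within the scatter) in this assay. Set beside the earlier case, the change gives steps that do not differ between the two cores, which means that a step seen on one core gave a fair guide to the step on the other: the same change on two cores in this assay, a number 10 percentage points lower (within the scatter) from compound 2 to compound 1 and a number 8 percentage points lower (within the scatter) from compound 3 to compound 4, 2 percentage points apart, within the scatter of two such steps

This does not show that the change has a real effect on the cells, since each step on its own stays within the scatter, and agreement between two small steps may be no more than two readings that are close to no change at all; it also rests on just two pairs of compounds, one cell line and a single tested concentration, and says nothing about potency or about any other core.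

The compounds shown leave open whether another group on the same aromatic carbon, such as a fluorine atom, a hydroxy group or a longer ethoxy chain, would give a step beyond the scatter. On these data alone, it also remains open whether the same change would read alike on a core that carries a carboxylic acid.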